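Two-Substituted Aryl Swap in Ecdysone Receptor Agonist Hydrazides

The source may report more compounds than this note shows. Statements on the series, on what has been measured and on what is new or still open speak of the compounds shown alone.

The measured compounds:
- compound 1 `COc1ccccc1C(=O)N(NC(=O)c1ccccc1)C(C)(C)C`, giving 525 nM in an assay on cells for agonist activity at ecdysone receptor (Bombyx mori), read by a luciferase reporter, with a stated time of 24 h; a lower number here means that less compound is needed, a higher number that more compound is needed for the effect
- compound 2 `CC(C)(C)N(NC(=O)c1ccccc1I)C(=O)c1ccccc1Cl`, giving 1290 nM in this assay
- compound 3 `CC(C)c1ccc(C(=O)NN(C(=O)c2ccccc2Cl)C(C)(C)C)cc1`, giving 24.6 nM in this assay

Among the three compounds measured so far, compound 2 stands at the highest number. Compound 1 sits nearest to it, at a lower number that is beyond the scatter of the measurement, while compound 3 lies furthest away, at a much lower number, also well beyond the scatter. Compound 3 thus shows how far the shared core can be pushed toward lower numbers when the hydrazide-side aryl group is changed.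

Compound 4 `Cc1ccc(C(=O)NN(C(=O)c2ccccc2Cl)C(C)(C)C)c(C)c1` has not yet been measured. It differs from compound 2 in one place: 2,4-dimethylphenyl in place of 2-iodophenyl on a carbonyl carbon.

Given that compound 3, with a substituted phenyl group on the same carbonyl carbon, gives 24.6 nM, a move to a lower number in this assay seems likely for compound 4, though the substitution pattern of compound 4 is not that of compound 3, so the step is expected to be smaller than the gap between compound 2 and compound 3. The estimate means a step of an 8.6-fold lower number from compound 2 to compound 4 (0.93 log units; beyond the scatter). Compound 4 is expected to give 150 nM, with a range from 40 nM to 600 nM.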

Compound 4, half-maximal effective concentration: 162 nM
Compound 4: middle estimate off by 1.1-fold (0.03 log units), on the low side; low and high end bracket the measured number.
By their numbers in this assay, from the lowest: compound 3; then compound 4; then compound 1; then compound 2.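

In this assay, among the compounds shown here, 2,4-dimethylphenyl in place of 2-iodophenyl, on the carbonyl carbon whose other neighbour is the amide-type nitrogen, gives an 8.0-fold lower number from compound 2 to compound 4 (0.90 log units; beyond the scatter) and is the first step in this set that changes one place alone. It shows that this position responds to the aryl group while the rest of the molecule stays fixed, even though both groups are a six-membered aromatic ring of carbon only, with no hydrogen-bond donors or acceptors and no net charge, so those counts do not separate them. No independent evidence bears on why the number falls with this change.

The compounds shown leave open which part of the change carries the step, the loss of the iodine or the gain of one or both methyl groups, a question that a 2-methylphenyl or a 2-bromophenyl group on this carbonyl carbon would help to settle. Also open, as far as these compounds go, is how the position would respond to a ring carrying an amine or a carboxylic acid, or a longer chain in place of the methyl groups.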